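Chloro for hydrogen on the benzyl group: solubility outlook

A few compounds are considered here, and "the series" means these few. Any claim that something is new, unique, unknown or untested is made for them only; others in the source may bear on it.

Compound 2 `NC(=O)c1ccc2[nH]c(-c3ccc(OCCC4CCCCN4Cc4ccccc4)cc3)nc2c1`: > 400000 nM
Compound 1 `COc1ccc(CN2CCCC(COc3ccc(-c4nc5cc(C(N)=O)ccc5[nH]4)cc3)C2)cc1`: "not determined" (no result reported)

In a physicochemical assay for solubility, with a stated time of 3 days, at pH 2 (on this read-out higher numbers stand for higher solubility and lower numbers for lower solubility), compound 2 reaches only a limit, > 400000 nM, and the data give it no single number. Among the measured compounds shown here, compound 1, in this assay, gives "not determined" (no result reported), so there is no measured step to lean on. Compound 3 `NC(=O)c1ccc2[nH]c(-c3ccc(OCCC4CCCCN4Cc4ccc(Cl)cc4)cc3)nc2c1` differs from compound 2 by one change: chloro in place of hydrogen on an aromatic carbon. For the measured compounds named here, with no measured step and only one limit as evidence (the limit of > 400000 nM in this assay, at which 1 of the 2 values shown sits), the step of an at least 1.1-fold lower number from compound 2 to compound 3 (0.05 log units; that floor lies within the scatter) is expected to stay within the usual scatter. For compound 3 the solubility is therefore estimated at 350000 nM, within 80000 nM to 1000000 nM.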

Compound 3, solubility: > 400000 nM
Compound 3 ended at the assay's limit (the forecaster's own chance of this, stated with the estimate: 55%); middle value at least 1.1-fold (0.05 log units) from the limit.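

Among the compounds shown here, no step from compound 2 to compound 3 can be read in this assay: both results are limits of the assay. The compounds shown leave open how far either lies past that limit, and whether chloro in place of hydrogen shifts solubility at all.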